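Benzyl removal in three measured compounds and one pending

The compounds below may be only part of what the source reports. "The series", "measured", "known", "first", "only" and "open" are said of these compounds alone.

Compound 1 `C[Si](C)(C)CCOCn1c(CC(O)COCc2ccccc2)cc(=O)[nH]c1=O` gives in a functional assay on HeLa cells (Homo sapiens) for antiproliferative activity, read by MTT assay, with a stated time of 72 h (a higher number here means a weaker inhibitor, a lower number a stronger inhibitor), only a limit, > 100000 nM.
Compound 2 `C[Si](C)(C)CCOCn1c(CC(O)CO)cc(=O)[nH]c1=O` gives in this assay only a limit, > 100000 nM.
Compound 3 `COCn1c(CC(O)COCc2ccccc2)c(C)c(=O)[nH]c1=O` gives in this assay only a limit, > 100000 nM.

All three measured values sit at the limit of > 100000 nM in this assay, at which 3 of the 3 values shown sit. Compound 1 and compound 2 differ by hydrogen in place of benzyl on an oxygen on a saturated carbon; the step that the two limits leave unreadable from compound 1 to compound 2 cannot be read because the limit of > 100000 nM in this assay, at which 3 of the 3 values shown sit, holds both ends. The difference between the core of compound 1 and the core of compound 3 is not broken down here.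

Compound 4 `COCn1c(CC(O)CO)c(C)c(=O)[nH]c1=O` differs from compound 3 by hydrogen in place of benzyl on an oxygen on a saturated carbon, the same change as from compound 1 to compound 2, at a place described in the same words. Compound 4 is expected at 100000 nM, between 30000 nM and 300000 nM. The expected step of a number no higher from compound 3 to compound 4 (the limit leaves the size open) rests on compound 3 being at the limit of > 100000 nM in this assay, at which 3 of the 3 values shown sit, and on a step that the two limits leave unreadable from compound 1 to compound 2 being unreadable.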

Compound 4, half-maximal inhibitory concentration: > 100000 nM
Compound 4 was reported as a limit; the forecaster's own chance of this, stated with the estimate: 80%; the middle value sits exactly at the limit.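

Going by these compounds alone, compound 3 and compound 4 are both reported only as limits in this assay, so no step between them can be read: the limit of > 100000 nM in this assay, at which 4 of the 4 values shown sit. The compounds shown leave open whether hydrogen in place of benzyl changes antiproliferative activity on either core.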